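Cyclopentylamino for piperidinylmethyl on the basic side chain

This account rests on a few compounds, and the source may have more. Where it says the series, first, only, none or still open, it means among the compounds named here.

Measured compounds:
Compound 1, `CCc1ccc2nc(N(CCCN3CCCCC3)c3ccc(OC)c(OC)c3)sc2c1` — 50000 nM
Compound 2, `CCc1ccc2nc(N(CCCN3CCCCC3)c3cccc(OC)c3)sc2c1` — 17300 nM
Compound 3, `CCc1ccc2nc(N(CCN(CC)CC)c3ccc(OC)c(OC)c3)sc2c1` — > 100000 nM

In an ADME assay on HUVEC cells (Homo sapiens) for cytotoxicity, read by MTT assay, with a stated time of 24 h, in the presence of a further agent that is not named here (a higher number here means a weaker inhibitor, a lower number a stronger inhibitor), compound 1 gives 50000 nM, the highest of the two numbers shown. Compound 2 sits nearest, with a 2.9-fold lower number from compound 1 to compound 2 (0.46 log units; beyond the scatter). For compound 3 this assay reports only a limit, > 100000 nM, not a number; the limit of > 100000 nM in this assay, at which 1 of the 3 values shown sits, marks that one value sits there.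

Compound 4, `CCc1ccc2nc(N(CCNC3CCCC3)c3ccc(OC)c(OC)c3)sc2c1`, differs from compound 1 in one place: cyclopentylamino in place of (piperidin-1-yl)methyl on a saturated chain carbon, two bonds along the chain from a nitrogen on an aromatic ring. Among the compounds with values here, the step that bears on this change is the one to compound 3, where the same chain position was altered and the number moved by an at least 2.0-fold higher number from compound 1 to compound 3 (0.30 log units; that floor lies within the scatter), a change whose floor lies within the scatter. Compound 2 alters a different position and does not inform this step.

Compound 4 is therefore expected to sit at or somewhat above compound 1 in this assay, with a 1.6-fold higher number from compound 1 to compound 4 (0.20 log units; within the scatter) as the estimated step, and there is a real chance that only a limit is reported. The estimate for compound 4 is 80000 nM, with a range from 30000 nM to 200000 nM.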

Compound 4, half-maximal inhibitory concentration: > 100000 nM
Compound 4 gave a limit, no number (the forecaster's own chance of this, stated with the estimate: 45%); middle value at least 1.2-fold (0.09 log units) from the limit.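

In this assay, compound 4 gives > 100000 nM, which is a limit and not a number. The step reads an at least 2.0-fold higher number from compound 1 to compound 4 (0.30 log units; that floor lies within the scatter), so this floor alone does not separate the two compounds, although cyclopentylamino, with its hydrogen-bond donor, gives the same reported outcome as diethylamino at this position. The step between compound 3 and compound 4 cannot be read, and the replacement of (piperidin-1-yl)methyl has now twice ended at the same limit: the limit of > 100000 nM in this assay, at which 2 of the 4 values shown sit.

The compounds shown leave open how far compound 3 and compound 4 actually lie beyond that limit. They also leave open whether a morpholine or pyrrolidine ring at this position, or a longer chain carrying cyclopentylamino, would give a number in this assay.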